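Swapping the Chain Cap of an Anilide Compound

A few compounds are considered here, and "the series" means these few. Any claim that something is new, unique, unknown or untested is made for them only; others in the source may bear on it.

Compound 1, `NC(=O)C(=O)NCCCCCC(=O)Nc1ccccc1`, gives > 100000 nM in a functional assay on HCT-116 cells (Homo sapiens) for inhibition, read by colorimetric assay, with a stated time of 3 days; a higher number here means a weaker inhibitor, a lower number a stronger inhibitor; that reading is a limit of the assay, not a number.
Compound 2, `O=C(CCCCCCNC(=O)C(O)(O)C(F)(F)F)Nc1ncc(-c2ccccc2)s1`, gives 2660 nM in this assay.
Compound 3, `O=C(CCCCCCNC(=O)C(O)(O)C(F)(F)F)Nc1ccc(S(F)(F)(F)(F)F)cc1`, gives 9110 nM in this assay.

As far as these compounds go, compound 1 stands only at the limit of the assay (the limit of > 100000 nM in this assay, at which 1 of the 3 values shown sits), so its true value is unknown. Within the data shown here, compound 2 and compound 3 differ from compound 1 in more than one place, so no single measured step connects them to it. Compound 4, `CC(C)(C)C(O)(O)C(=O)NCCCCCC(=O)Nc1ccccc1`, differs from compound 1 by 1,1-dihydroxy-2,2-dimethylpropyl in place of carbamoyl on a carbonyl carbon. Among the measured compounds shown here, no measured step shows the effect of this change, so any expectation is uncertain and a value near the limit remains possible. Compound 4 is expected to give 70000 nM, with a range from 15000 nM to 200000 nM, which corresponds to an expected step of an at least 1.4-fold lower number from compound 1 to compound 4 (0.15 log units; that floor lies within the scatter).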

Compound 4, half-maximal inhibitory concentration: 54400 nM
Estimate against measurement, compound 4: 1.3-fold (0.11 log units) above; measured number inside the range.
By their numbers in this assay, from the lowest: compound 2; then compound 3; then compound 4. At a limit, above all of these: compound 1.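

On the carbonyl carbon, 1,1-dihydroxy-2,2-dimethylpropyl in place of carbamoyl gives an at least 1.8-fold lower number from compound 1 to compound 4 (0.26 log units; that floor lies within the scatter). That step is only a floor and cannot be called a real gain, because compound 1 stands at a limit of the assay: the limit of > 100000 nM in this assay, at which 1 of the 4 values shown sits. Compound 4 does carry a measured number, so further changes at this position now have a reference point. As far as these compounds go, whether a carboxylic acid or an amine in this place would give a lower number stays open. So does whether a longer chain would shift the reading with this cap.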